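Amide Ring Swaps on a Shared Core, Read Only as Limits

The source may hold more compounds than are shown below. What is called first, only, known or untested is meant among the compounds shown, and "the series" means these compounds.

Compound 1 `CS(=O)(=O)c1ccc(C(=O)Nc2ccc(Cl)c(-c3nnc4c(Cl)cccn34)c2)c(Cl)c1` gives > 100000 nM in a functional assay on MCF7 cells (Homo sapiens) for antiproliferative activity, read by MTT assay, with a stated time of 72 h; on this read-out higher numbers stand for weaker inhibition and lower numbers for stronger inhibition.
Compound 2 `O=C(Nc1ccc(Cl)c(-c2nnc3c(Cl)cccn23)c1)c1ccccc1` gives > 100000 nM.
Compound 3 `Cc1nc(C(=O)Nc2ccc(Cl)c(-c3nnc4c(Cl)cccn34)c2)cs1` gives > 100000 nM.

Each of these three values is a limit of the assay, not a number. Compound 3 stands at the limit (the limit of > 100000 nM in this assay, at which 3 of the 3 values shown sit), where every shown value sits, so no order among the three can be read. Going by the values given here, the one single-point step among the measured compounds, a step that the two limits leave unreadable from compound 2 to compound 3, is unreadable for that reason.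

Compound 4 `O=C(Nc1ccc(Cl)c(-c2nnc3c(Cl)cccn23)c1)c1cccc(Cl)c1` differs from compound 3 by 3-chlorophenyl in place of 2-methyl-1,3-thiazol-4-yl on a carbonyl carbon. Among the compounds with values here, the only measured step bearing on a change at this carbonyl carbon is a step that the two limits leave unreadable from compound 2 to compound 3, and its size cannot be read. Nothing measured here gives a direction, so the expected step that the limit leaves unreadable from compound 3 to compound 4 is estimated as none beyond the scatter. Compound 4 is therefore estimated at 150000 nM, in the range 40000 nM to 600000 nM, most probably reported again only as a limit.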

Compound 4, half-maximal inhibitory concentration: 71900 nM
For compound 4 the middle estimate is 2.1-fold (0.32 log units) above the measured one; low and high end bracket the measured number.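

Going by these compounds alone, compound 4 is the first compound in this assay to give a number and not a limit, so a change on this carbonyl carbon now has a floor: there is an at least 1.3-fold lower number from compound 3 to compound 4 (0.14 log units; that floor lies within the scatter), and there is an at least 1.3-fold lower number from compound 2 to compound 4 (0.14 log units; that floor lies within the scatter). Both floors lie within the scatter, so neither 3-chlorophenyl in place of 2-methyl-1,3-thiazol-4-yl nor chloro in place of hydrogen is shown to make a real difference, though the true steps could be larger. Most values here remain limits: the limit of > 100000 nM in this assay, at which 3 of the 4 values shown sit.

From the compounds shown here alone, whether an aromatic ring carrying an amine or a carboxylic acid on this carbonyl carbon would give a clearly lower number stays open. So does the outcome of a longer chain there in place of a ring.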